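Chlorophenyl step in a series sitting at the limit

A few compounds are considered here, and "the series" means these few. Any claim that something is new, unique, unknown or untested is made for them only; others in the source may bear on it.

Measured in a functional assay on NCI-H460 cells (Homo sapiens) for cytotoxicity, read by sulforhodamine B assay; a lower number here means that less compound is tolerated, a higher number that more compound is tolerated:
- compound 1 `CC1=CC[C@@H]([C@@](C)(O)CCCC(C)(C)NC=S)CC1`: > 100000 nM (a limit)
- compound 2 `COc1ccc(/C=N\NC(=S)NC(C)(C)CCC[C@](C)(O)[C@@H]2CC=C(C)CC2)cc1`: > 100000 nM (a limit)
- compound 3 `CC1=CC[C@@H]([C@@](C)(O)CCCC(C)(C)NC(=S)N/N=C\c2ccc(N(C)C)cc2)CC1`: > 100000 nM (a limit)

Compound 3 gives no number in this assay and stands only at a limit (> 100000 nM). The other two measured compounds also stand only at a limit, so the series has not yet produced a readable value.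

The next structure is compound 4 `CC1=CC[C@@H]([C@@](C)(O)CCCC(C)(C)NC(=S)N/N=C\c2cccc(Cl)c2)CC1`, with 3-chlorophenyl in place of 4-(dimethylamino)phenyl on a carbon with a double bond to nitrogen. Within the data shown here, the one measured step that bears on this change is a step that the two limits leave unreadable from compound 2 to compound 3 and it supplies no size to carry over.

With compound 3 resting on (the limit of > 100000 nM in this assay, at which 3 of the 3 values shown sit), no step beyond the scatter is expected from this change, in either direction. The expected size is a number no higher from compound 3 to compound 4 (the limit leaves the size open), an estimate of little weight while the starting point is only a limit. A report of compound 4 at the same limit is the likeliest outcome. The estimate for compound 4 is 100000 nM (expected range 40000 nM to 200000 nM).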

Compound 4, concentration lethal to 50% of the cells: > 100000 nM
Compound 4 ended at the assay's limit; the forecaster's own chance of this, stated with the estimate: 70%; the middle value lies on the limit itself.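

No new step can be read: compound 4, like compound 2 and compound 3, stands only at a limit in this assay, and the steps to compound 4 from compound 2 and from compound 3 have no readable size. The compounds shown leave open where the actual lethal concentration of any of them lies, and whether the aromatic group changes it: the limit of > 100000 nM in this assay, at which 4 of the 4 values shown sit.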